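A few compounds are considered here, and "the series" means these few. Any claim that something is new, unique, unknown or untested is made for them only; others in the source may bear on it.

- compound 1 `Fc1ccccc1/C=C/c1nnc(-c2ccc3c(c2)OCCO3)o1`: 402000 nM
- compound 2 `COc1ccc(/C=C/c2nnc(-c3ccc4c(c3)OCCO4)o2)cc1`: 312000 nM

In an ADME assay on HUVEC cells (Homo sapiens) for cytotoxicity, read by MTT assay, with a stated time of 24 h (a higher number here means that more compound is tolerated, a lower number that less compound is tolerated), compound 2 at 312000 nM cannot be told apart from compound 1, since the two numbers lie within the usual scatter. Compound 3 `Cc1ccccc1/C=C/c1nnc(-c2ccc3c(c2)OCCO3)o1` differs from compound 2 on a double-bonded chain carbon bound to a double-bonded chain carbon: 2-methylphenyl in place of 4-methoxyphenyl on a double-bonded chain carbon bound to a double-bonded chain carbon. Among the measured compounds shown here, only one measured step involves this place, and a 1.3-fold lower number from compound 1 to compound 2 (0.11 log units; within the scatter) is small. With so little evidence, no step beyond the scatter is expected in this assay. The expected change is a 1.1-fold higher number from compound 2 to compound 3 (0.05 log units; within the scatter). For compound 3 the estimated value is 350000 nM, with an expected range from 180000 nM to 680000 nM.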

Compound 3, half-maximal cytotoxic concentration: 356000 nM
The estimate for compound 3 lay 1.0-fold (0.01 log units) below the measured number, and the stated range covers the measured number.
By their numbers in this assay, from the lowest: compounds 2, 3 and 1 (each within the scatter of the next).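

In this assay, 2-methylphenyl in place of 4-methoxyphenyl gives a 1.1-fold higher number from compound 2 to compound 3 (0.06 log units; within the scatter), while methyl in place of fluoro on an aromatic carbon gives a 1.1-fold lower number from compound 1 to compound 3 (0.05 log units; within the scatter), so neither change can be told from the scatter. All three aromatic groups tried at this place, including one with no hydrogen-bond acceptor, therefore give numbers that cannot be told apart. No measured information is available to explain this. Going by these compounds, whether this holds for a quite different group at this place, such as an amine or a carboxylic acid, stays open.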